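The compounds below may be only part of what the source reports. "The series", "measured", "known", "first", "only" and "open" are said of these compounds alone.

The compounds measured so far:

compound 1, `C=CCn1c(=O)n(C2CCC(CO)C2)c2nc(N)nc(O)c21`: 26%
compound 2, `C=CCn1c(=O)n([C@H]2CO[C@@H](CO)C2)c2nc(N)nc(O)c21`: 10%
compound 3, `C=CCn1c(=O)n(C2OC(CO[Si](C)(C)C(C)(C)C)[C@@H](O)[C@H]2O)c2nc(N)nc(O)c21`: 5%

In a functional assay on the whole organism (B cells) with Mus musculus as the target (on this read-out higher numbers stand for larger maximal responses and lower numbers for smaller maximal responses), compound 2 gives 10%, the second highest of the three numbers. Its nearest neighbour is compound 3, which in this assay gives 5%, a gap that lies within the scatter. Within the data shown here, the furthest is compound 1, reached by the one step that has been measured, a number 16 percentage points lower from compound 1 to compound 2 (beyond the scatter).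

Compound 4, `C=CCn1c(=O)n(Cc2ccccc2)c2nc(N)nc(O)c21`, has not been measured. It differs from compound 2 in one place: a group of 7 heavy atoms (7 carbon; one six-membered aromatic ring of carbon only) in place of a group of 7 heavy atoms (5 carbon, 2 oxygen; one five-membered non-aromatic ring with 1 hetero atom), on an aromatic nitrogen.

Among the measured compounds shown here, only that measured step bears on this change, since it also replaced one group on the same aromatic nitrogen and gave a modest loss. For the measured compounds named here, no measured pair contains a benzyl group, so the direction of the new change cannot be read from the data. The nearest guide, compound 1 with 26%, suggests that removing the oxygen-containing ring need not lower the response. For compound 4 the step of a number 8 percentage points higher from compound 2 to compound 4 (within the scatter) is therefore expected to be small, at or near the scatter. The response of compound 4 is estimated at 18%, within a range of 5% to 40%.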

Compound 4, largest response reached (reported as maximal response), in percent of the reference or control that the assay uses: 25%
Compound 4: middle estimate off by 7 percentage points, on the low side; the measured number falls inside the stated range.
By their numbers in this assay, from the lowest: compounds 3 and 2 (each within the scatter of the next); then compounds 4 and 1 (each within the scatter of the next).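

In this assay, putting benzyl on the aromatic nitrogen gives a number 15 percentage points higher from compound 2 to compound 4 (beyond the scatter), so this position accepts a carbon-only aromatic ring, with no hydrogen-bond donor or acceptor, in place of the five-membered ring with one hetero atom. The change to benzyl from the group of compound 1 gives a number 1 percentage points lower from compound 1 to compound 4 (within the scatter), so these two groups cannot be told apart here, and the oxygen still carried by the group of compound 1 is not needed to reach this level of response. No measurement available here explains these differences.

The compounds shown leave open whether an open butyl chain without any ring would hold the response at this nitrogen. They also leave open what an amine or a carboxylic acid on the benzyl ring would do.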